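Saturated ring in place of one anilino phenyl on the core

The compounds below may be only part of what the source reports. "The series", "measured", "known", "first", "only" and "open" are said of these compounds alone.

Measured so far:
compound 1 `Fc1cc(F)c(Nc2nc3nonc3nc2Nc2c(F)cc(F)cc2F)c(F)c1` — 1100 nM
compound 2 `CCc1ccc(Nc2nc3nonc3nc2Nc2ccc(CC)cc2)cc1` — 3900 nM
compound 3 `Fc1ccccc1Nc1nc2nonc2nc1Nc1ccccc1` — 2200 nM

Three compounds share the core of compound 3 with two amine substituents on it. In an assay on mitochondria from L6 cells (Rattus norvegicus) for activation, with a stated time of 90 min (a higher number here means that more compound is needed for the effect, a lower number that less compound is needed), compound 1 gives 1100 nM, compound 2 gives 3900 nM and compound 3 gives 2200 nM. The gap from compound 3 to compound 2 lies within the usual scatter, and so does the gap from compound 3 to compound 1; compound 3 therefore stands apart from neither, and the three values read as one group.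

Compound 4 `Fc1ccccc1Nc1nc2nonc2nc1NC1CCCCC1` has not yet been measured in this assay. It is derived from compound 3 by one change: cyclohexyl in place of phenyl on a nitrogen on an aromatic ring. Going by these compounds, all measured compounds carry aromatic rings on both nitrogens, so the effect of a non-aromatic ring there is untested and cannot be anchored on a recorded step.

For compound 4 the expectation is a step to a higher number, a 1.8-fold higher number from compound 3 to compound 4 (0.26 log units; within the scatter), somewhat beyond the scatter, and the value is estimated at 4000 nM with a range from 1500 nM to 12000 nM.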

Compound 4, half-maximal effective concentration: 13400 nM
Beside the measured number, compound 4's estimate is 3.4-fold (0.53 log units) below it, and the stated range ends below it.
By their numbers in this assay, from the lowest: compounds 1, 3 and 2 (each within the scatter of the next, the first and the last beyond it); then compound 4.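

In this assay, within the data shown here, cyclohexyl in place of phenyl on a nitrogen on an aromatic ring gives a 6.1-fold higher number from compound 3 to compound 4 (0.78 log units; beyond the scatter), a step beyond the scatter, whereas the three earlier compounds, all with aromatic rings on both nitrogens, formed one group and offered no recorded step. The leaving and entering groups are both six-membered rings of carbon only, so in this single pair the higher number goes with the change from an aromatic to a non-aromatic ring, not with a change in ring size. No available evidence bears on the reason for this step.

Going by these compounds, whether a cyclopentyl ring, a piperidine ring or an open hexyl chain on this nitrogen would follow cyclohexyl remains open. Also open, on these data alone, is whether the same exchange on the other nitrogen would give a step of similar size.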